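The compounds below may be only part of what the source reports. "The series", "measured", "known", "first", "only" and "open" are said of these compounds alone.

Among the compounds with values here, compound 2 `Cn1ccc2ccc(-c3cc(Nc4cnccc4C(=O)NCc4cncnc4)cc4nccnc34)cc21` stands at 49500 nM in an assay on lysate for inhibition of 6-phosphofructo-2-kinase/fructose-2,6-bisphosphatase 3 (Homo sapiens), with stated times of 0.5 min and 45 min (a lower number here means a stronger inhibitor, a higher number a weaker inhibitor), and that is the only plain number recorded here. Compound 1 `Cn1ccc2ccc(-c3cc(Nc4ccccc4S(=O)(=O)Nc4cncnc4)cc4nccnc34)cc21` reaches only a limit of > 100000 nM in this assay, and one of the two values sits at this limit (the limit of > 100000 nM in this assay, at which 1 of the 2 values shown sits). Compound 3 `CN1CCC(NC(=O)c2ccncc2Nc2cc(-c3ccc4ccn(C)c4c3)c3nccnc3c2)CC1=O` differs from compound 2 by 1-methyl-2-oxopiperidin-4-yl in place of (pyrimidin-5-yl)methyl on an amide-type nitrogen, a change on an amide-type nitrogen whose other neighbour is a carbonyl carbon. Within the data shown here, no measured pair differs in just this one place, so nothing can be borrowed. The step from compound 2 to compound 3 is expected to be a 1.0-fold higher number from compound 2 to compound 3 (0.00 log units; within the scatter), nothing beyond the scatter. Compound 3 is therefore estimated at 50000 nM, within a range from 15000 nM to 150000 nM.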

Compound 3, half-maximal inhibitory concentration: 48800 nM
Compound 3: middle estimate off by 1.0-fold (0.01 log units), on the high side; low and high end bracket the measured number.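

On the amide-type nitrogen, the aromatic (pyrimidin-5-yl)methyl and the non-aromatic 1-methyl-2-oxopiperidin-4-yl prove interchangeable in this assay, with a step of a 1.0-fold lower number from compound 2 to compound 3 (0.01 log units; within the scatter). At this place, then, exchanging one six-membered ring for a clearly different one leaves the number where it was. Nothing measured here explains why.

Still open, from the compounds shown here alone, is whether a chain ending in an amine, or a carboxylic acid, would move the number at this nitrogen. Also open, going by these compounds, is whether any group here can bring it far lower.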